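This account rests on a few compounds, and the source may have more. Where it says the series, first, only, none or still open, it means among the compounds named here.

Measured compounds in the series:

- compound 1 `COc1cccc2c1C=C(CC1CN=CN1)CC2`: 158 nM
- compound 2 `Cc1cccc2c1C=C(CC1CN=CN1)CC2`: 631 nM
- compound 3 `COc1ccc2c(c1)C=C(CC1CN=CN1)CC2`: 2510 nM

All three were tested in an assay on isolated protein for binding affinity to Adrenergic receptor alpha-1 (Rattus norvegicus), read by radioligand binding, in the presence of a further agent that is not named here; a higher number here means a weaker inhibitor, a lower number a stronger inhibitor. Compound 1 gives 158 nM and compound 2 gives 631 nM; the change between them, (methyl in place of methoxy on an aromatic carbon), produced a 4.0-fold higher number from compound 1 to compound 2 (0.60 log units; beyond the scatter). Compound 3 gives 2510 nM, the highest of the three numbers, with its nearest neighbour being compound 2 and the widest gap to compound 1. Compound 1 and compound 3 have the same atoms joined differently; the difference between the two cores is not broken down here.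

Compound 4 `Cc1ccc2c(c1)C=C(CC1CN=CN1)CC2` has not been measured in this assay. It differs from compound 3 by methyl in place of methoxy on an aromatic carbon. This is the same kind of change as that from compound 1 to compound 2, though not the same: there the group sat "ortho to a fused ring; meta to a fused ring", here it sits "meta to a fused ring; para to a fused ring". Within the data shown here, only one measured instance of the change exists, so the expectation rests on it alone. Because compound 2 gave a 4.0-fold higher number from compound 1 to compound 2 (0.60 log units; beyond the scatter) relative to compound 1, a step in the same direction is expected for compound 4, estimated as a 2.5-fold higher number from compound 3 to compound 4 (0.40 log units; beyond the scatter), with wide bounds given the change in place. Compound 4 is therefore estimated at 6300 nM in this assay, expected to fall between 2000 nM and 20000 nM.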

Compound 4, inhibition constant: 398 nM
Compound 4: the middle estimate sits 16-fold (1.20 log units) above what was measured, outside the stated range (below it).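

Working notes on the methoxy-to-methyl change: in this assay, methyl in place of methoxy on an aromatic carbon gave a 6.3-fold lower number from compound 3 to compound 4 (0.80 log units; beyond the scatter), which runs opposite to the earlier 4.0-fold higher number from compound 1 to compound 2 (0.60 log units; beyond the scatter). The step measured on one core therefore did not carry over to the other, either in direction or in size: the same change on two cores in this assay, a 4.0-fold higher number (0.60 log units; beyond the scatter) from compound 1 to compound 2 and a 6.3-fold lower number (0.80 log units; beyond the scatter) from compound 3 to compound 4, 25-fold (1.40 log units) apart, beyond the scatter of two such steps This shows that, within these two pairs, the outcome of the change depends on the core that carries it, but with a single pair on each core it gives neither a rule for the series nor a reason for the reversal, and it does not separate the place of the group on the aromatic ring from any other difference between the cores.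

On these data alone, it remains open whether a hydroxyl, an ethoxy group or a chlorine atom on the same aromatic carbon would follow the pattern of compound 1 and compound 2 or that of compound 3 and compound 4. Also open, as far as these compounds go, is whether an amine or a longer chain at these places would split the two cores in the same way.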